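A 2-methyl-2H-tetrazol-5-yl group on compound 1

The source may hold more compounds than are shown below. What is called first, only, known or untested is meant among the compounds shown, and "the series" means these compounds.

In a physicochemical assay for solubility, in phosphate buffer, at pH 7.4 (a higher number here means a more soluble compound, a lower number a less soluble compound), compound 1 `CCNC(=O)Nc1nc2cc(-c3cccnc3)c(=O)n(C(C)C)c2s1` gives 42000 nM and compound 2 `CCNC(=O)Nc1nc2cc(-c3cccnc3)c(=O)n(CC3CCOCC3)c2s1` gives 25000 nM. These two numbers lie within the scatter of each other, and (oxan-4-yl)methyl in place of isopropyl on an aromatic nitrogen gives a 1.7-fold lower number from compound 1 to compound 2 (0.23 log units; within the scatter). Compound 3 `CCNC(=O)Nc1nc2cc(-c3cncc(OC)c3)c(=O)n(C(C)C)c2s1` reads < 5000 nM, which is a limit. Compound 4 `CCNC(=O)Nc1nc2cc(-c3ccc(-c4nnn(C)n4)nc3)c(=O)n(C(C)C)c2s1` carries 2-methyl-2H-tetrazol-5-yl in place of hydrogen on an aromatic carbon. The nearer precedent is also a change on an aromatic carbon, methoxy in place of hydrogen, which gave an at least 8.4-fold lower number from compound 1 to compound 3 (0.92 log units; beyond the scatter). On that precedent, a drop beyond the scatter is expected, an estimated 8.4-fold lower number from compound 1 to compound 4 (0.92 log units; beyond the scatter). For compound 4 the expected value is 5000 nM, with an estimated range of 2000 nM to 15000 nM.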

Compound 4, solubility: 2000 nM
The estimate for compound 4 lay 2.5-fold (0.40 log units) above the measured number; low and high end bracket the measured number.
By their numbers in this assay, from the lowest: compound 4; then compounds 2 and 1 (each within the scatter of the next).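

In this assay, 2-methyl-2H-tetrazol-5-yl on an aromatic carbon next to the ring nitrogen gives a 21-fold lower number from compound 1 to compound 4 (1.32 log units; beyond the scatter), a large step and the first change at this position among the compounds shown. Compound 3 reads < 5000 nM, which is a limit and not a number, so its step cannot be ranked against this one: the limit of < 5000 nM in this assay, at which 1 of the 4 values shown sits.

From the compounds shown here alone, whether an amine or a carboxylic acid on this carbon would give a smaller step remains open. Also open, going by these compounds, is whether the same step would hold with the (oxan-4-yl)methyl of compound 2 on the aromatic nitrogen.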